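This account rests on a few compounds, and the source may have more. Where it says the series, first, only, none or still open, it means among the compounds named here.

Working notes on the series, following the step from compound 3 to compound 4 in a physicochemical assay for acid dissociation.

Compound 3 `CC(C)(C)c1ccc(-c2ccc3c(NCCCNCc4ccco4)ccnc3c2)cc1` gives 9.47. Compound 1 `COc1ccc(-c2ccc3c(NCCCNCc4cccc(OC)c4O)ccnc3c2)cc1` gives 9.47, and compound 2 `c1ccc(CCc2ccc3c(NCCCNCc4ccco4)ccnc3c2)cc1` gives 9.47; compound 3 therefore stands level with both at the digits shown, within the scatter of the measurement. Within the data shown here, the one measured step between neighbours, no change at the digits printed from compound 2 to compound 3 (within the scatter), left the read-out unchanged even though it exchanged the whole group on the aromatic carbon of the shared core.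

Compound 4 `COc1ccc(-c2ccc3c(NCCCNCc4ccco4)ccnc3c2)cc1` differs from compound 3 by methoxy in place of tert-butyl on an aromatic carbon. Among the measured compounds shown here, only that measured step bears on this change, and it was flat. Compound 1 carries the same 4-methoxyphenyl group, with a different group at the other end of the chain, and shows the same value as compound 3. No step beyond the scatter is expected, so the estimated step of no change at the digits printed from compound 3 to compound 4 (within the scatter) is essentially nil. Compound 4 is expected at 9.47, with a range from 9.17 to 9.77.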

Compound 4, acid dissociation constant: 9.47
For compound 4 middle estimate and measured number coincide at the digits printed; measured number inside the range.
By their numbers in this assay, from the lowest: compounds 1, 2, 3 and 4 (each within the scatter of the next).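

In this assay, methoxy in place of tert-butyl gives no change at the digits printed from compound 3 to compound 4 (within the scatter), and 4-methoxyphenyl in place of phenethyl gives no change at the digits printed from compound 2 to compound 4 (within the scatter), so a group with one hydrogen-bond acceptor and two heavy atoms now reads level with the earlier groups at this aromatic carbon. The far end of the chain now has its first single-place step: furan-2-yl in place of 2-hydroxy-3-methoxyphenyl gives no change at the digits printed from compound 1 to compound 4 (within the scatter), so the read-out is level across a change at each of the two places. No measured information accounts for this absence of any step.

On these data alone, whether a carboxylic acid or a primary amine on that aromatic carbon, or a longer chain leading to the furan-2-yl group, would shift the read-out stays open. The four values also do not tell which site in these compounds gives up the proton.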